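Extending the ether chain of compound 1 to decyl

The compounds below may be only part of what the source reports. "The series", "measured", "known", "first", "only" and "open" are said of these compounds alone.

In a functional assay on brain (Rattus norvegicus, strain Wistar) for inhibition (on this read-out lower numbers stand for stronger inhibition and higher numbers for weaker inhibition), compound 1 `Cc1[nH]c(=O)n(C2CCCCC2)c1-c1ccc(OC(C)C)cc1` gives 13000 nM. Compound 2 `Cc1[nH]c(=O)n(C2CCCCC2)c1-c1ccc(CC(C)C)cc1` gives 10900 nM, within the scatter of compound 1, while compound 3 `Cc1[nH]c(=O)n(C2CCCCC2)c1-c1ccc(C2CCCCC2)cc1` gives 28900 nM, the highest number of the three. Compound 4 `CCCCCCCCCCOc1ccc(-c2c(C)[nH]c(=O)n2C2CCCCC2)cc1` differs from compound 1 as follows: decyl in place of isopropyl on an oxygen on an aromatic ring. Among the compounds with values here, no measured step lengthens a chain on that oxygen, so the nearest evidence comes from replacing the whole group on the aromatic carbon. There, a 1.2-fold lower number from compound 1 to compound 2 (0.08 log units; within the scatter) and a 2.2-fold higher number from compound 1 to compound 3 (0.35 log units; beyond the scatter). On these data alone, the largest such change, a 2.7-fold higher number from compound 2 to compound 3 (0.42 log units; beyond the scatter), is modest, so no step beyond the scatter is expected, although the direction remains open. The expected change is a 1.3-fold lower number from compound 1 to compound 4 (0.11 log units; within the scatter). For compound 4 the estimate is 10000 nM, with an expected range of 2500 nM to 40000 nM.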

Compound 4, half-maximal inhibitory concentration: 10500 nM
The estimate for compound 4 lay 1.1-fold (0.02 log units) below the measured number, within the range that was stated.
By their numbers in this assay, from the lowest: compounds 4, 2 and 1 (each within the scatter of the next); then compound 3.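

On the oxygen on an aromatic ring, decyl in place of isopropyl gives a 1.2-fold lower number from compound 1 to compound 4 (0.09 log units; within the scatter) in this assay. The earlier compounds shown here only exchanged the whole group on the aromatic carbon, whereas this step shows that a decyl chain on the oxygen leaves the number within the scatter of that with the isopropyl group. No measurement available here explains this outcome.

On these data alone, it remains open whether a butyl or hexyl chain on that oxygen would behave in the same way. A decyl chain ending in an amine or a carboxylic acid is likewise untested by the compounds shown.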